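Aryl swap on triazole in a quinoxaline-fused spirooxindole series

The source may report more compounds than this note shows. Statements on the series, on what has been measured and on what is new or still open speak of the compounds shown alone.

Measured in an ADME assay on L02 cells (Homo sapiens) for antiproliferative activity, read by MTT assay, with a stated time of 48 h; on this read-out higher numbers stand for weaker inhibition and lower numbers for stronger inhibition:
Compound 1 `N#CC1=C(N)Oc2c(c3nc4ccccc4nc3c3ccccc23)C12C(=O)N(Cc1cnnn1-c1ccc(Br)cc1)c1ccccc12` gives > 50000 nM, a limit of the assay.
Compound 2 `COc1ccc(-n2nncc2CN2C(=O)C3(C(C#N)=C(N)Oc4c3c3nc5ccccc5nc3c3ccccc43)c3ccccc32)cc1` gives > 50000 nM, a limit of the assay.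
Compound 3 `N#CC1=C(N)Oc2c(c3nc4ccccc4nc3c3ccccc23)C12C(=O)N(Cc1cnnn1-c1ccc(S(N)(=O)=O)cc1)c1ccccc12` gives > 50000 nM, a limit of the assay.

Compound 3 stands at the limit of this assay; nothing shown puts it apart from the others, as the limit of > 50000 nM in this assay, at which 3 of the 3 values shown sit, states. Compound 4 `N#CC1=C(N)Oc2c(c3nc4ccccc4nc3c3ccccc23)C12C(=O)N(Cc1cnnn1-c1cc(Cl)ccc1Cl)c1ccccc12` is not yet measured. Its change from compound 3 is 2,5-dichlorophenyl in place of 4-sulfamoylphenyl on an aromatic nitrogen. Going by the values given here, the steps that bear on this aryl position, a step that the two limits leave unreadable from compound 1 to compound 3, a step that the two limits leave unreadable from compound 2 to compound 3 and a step that the two limits leave unreadable from compound 1 to compound 2, all run between limits and give no readable size. Three changes of the aryl group have left this series at the limit, so compound 4 is expected to stay there, and the expected step that the limit leaves unreadable from compound 3 to compound 4 is none beyond the scatter. For compound 4 the estimate in this assay is 60000 nM, with a range from 20000 nM to 200000 nM.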

Compound 4, half-maximal inhibitory concentration: > 50000 nM
Compound 4: a limit, no number (the forecaster's own chance of this, stated with the estimate: 80%); the middle value does not contradict the limit.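

The result for compound 4 is again a limit, so no step among compound 1, compound 2, compound 3 and compound 4 can be read in this assay: the limit of > 50000 nM in this assay, at which 4 of the 4 values shown sit.

Still open, on these data alone, is how these four compounds differ beyond that limit, and whether any aryl group at this position gives a readable value.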